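A few compounds are considered here, and "the series" means these few. Any claim that something is new, unique, unknown or untested is made for them only; others in the source may bear on it.

In an ADME assay on microsomes from liver (Mus musculus, strain NMRI) for metabolic stability, tested at 2.5 uM (on this read-out lower numbers stand for slow clearance and higher numbers for fast clearance), compound 1 `Clc1ccc(Cn2nnc3c(Br)cccc32)cc1` gives 2 mL/min/g, and compound 2 `Brc1ccc(Cn2nnc3c(Br)cccc32)cc1` gives 2.6 mL/min/g. The two differ by chloro in place of bromo on an aromatic carbon, a change that made a 1.3-fold lower number from compound 2 to compound 1 (0.11 log units; within the scatter). Compound 3 `Brc1cc(Br)c2nnn(CC3CC3)c2c1` gives 15.3 mL/min/g in this assay, the highest of the three numbers; how its core differs from the core of compound 2 is not broken down here. Compound 4 `Clc1cc(Br)c2nnn(CC3CC3)c2c1` has not yet been measured. It differs from compound 3 by chloro in place of bromo on an aromatic carbon, the same kind of change as that from compound 2 to compound 1, though here the place is meta to a bromo group, meta to a fused ring and para to a fused ring, whereas in compound 1 it is para to a large group. Because a 1.3-fold lower number from compound 2 to compound 1 (0.11 log units; within the scatter) stayed within the scatter, compound 4 is expected to show a 1.2-fold lower number from compound 3 to compound 4 (0.07 log units; within the scatter) in this assay. Compound 4 is therefore estimated at 13 mL/min/g, with a range from 7 mL/min/g to 25 mL/min/g.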

Compound 4, intrinsic clearance in a liver preparation (reported as CLH), per the amount of preparation that the assay uses: 11.4 mL/min/g
Beside the measured number, compound 4's estimate is 1.1-fold (0.06 log units) above it; measured number inside the range.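

In this assay, chloro in place of bromo on an aromatic carbon gives a 1.3-fold lower number from compound 3 to compound 4 (0.13 log units; within the scatter). Set beside the earlier step, the change reads the same on both cores: the same change on two cores in this assay, a 1.3-fold lower number (0.11 log units; within the scatter) from compound 2 to compound 1 and a 1.3-fold lower number (0.13 log units; within the scatter) from compound 3 to compound 4, 1.0-fold (0.01 log units) apart, within the scatter of two such steps This shows that the swap carried over between these two cores without a step beyond the scatter, even though it sits at a different place on each, but two pairs cannot show that it would carry to any other core in the series, and they do not explain why the number stays within the scatter.

The compounds shown leave open what a group other than a halogen, such as an amine or a carboxylic acid, would do at these places. They also leave open whether the same swap at the remaining bromo group of compound 4 would read the same way.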